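Bromo for Methoxy on the Aniline Ring

The source may report more compounds than this note shows. Statements on the series, on what has been measured and on what is new or still open speak of the compounds shown alone.

The measured compounds and their values:
- compound 1, `Clc1ccccc1NCc1nc2ccc(Br)cc2[nH]1`, 23.5%
- compound 2, `COc1ccc(NCc2nc3ccccc3[nH]2)cc1`, 29.4%
- compound 3, `COc1ccc(NCc2nc3ccc(Br)cc3[nH]2)cc1`, 17.6%

In a functional assay on the whole organism (strain albino) for inhibition, with Rattus norvegicus as the target, read by paw edema, with a stated time of 120 min, at a dose of 100 mg/kg by the oral route (on this read-out lower numbers stand for less inhibition and higher numbers for more inhibition at the one dose given (going by the name of the read-out)), compound 2 gives 29.4%, the highest of the three numbers. Compound 1 sits closest to it, and the two lie within the scatter of each other, so no order between them can be claimed. Compound 3 sits furthest away: the step of a number 11.8 percentage points lower from compound 2 to compound 3 (beyond the scatter) is modest but beyond the scatter, and it comes from bromo in place of hydrogen on an aromatic carbon of the shared core.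

Compound 4, `Brc1ccc(NCc2nc3ccccc3[nH]2)cc1`, has not yet been measured. Compared with compound 2 the change is bromo in place of methoxy on an aromatic carbon, on an aromatic carbon of a six-membered aromatic ring of carbon only, para to a large group. Within the data shown here, no measured pair shows this exact swap. Among the measured compounds shown here, the only step in hand, a number 11.8 percentage points lower from compound 2 to compound 3 (beyond the scatter), puts a bromo onto a different ring, and compound 1, which carries a halogen on the aniline ring together with bromo on the core, gives 23.5%. Taken together these hint that adding a bromo tends not to raise the number, so a small drop or no change beyond the scatter is expected, a number 7.4 percentage points lower from compound 2 to compound 4 (within the scatter). Compound 4 is therefore estimated at 22%, in a range from 10% to 34%.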

Compound 4, a percentage reported as inhibition, in the whole organism at one dose (the size of the read-out at that dose, not a potency): 23.5%
Estimate against measurement, compound 4: 1.5 percentage points below; the measured number falls inside the stated range.
By their numbers in this assay, from the lowest: compounds 3, 1, 4 and 2 (each within the scatter of the next, the first and the last beyond it).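

In this assay, putting bromo where methoxy stood, on an aromatic carbon para to a large group, gives a number 5.9 percentage points lower from compound 2 to compound 4 (within the scatter), so at this position the two groups cannot be told apart in this read-out. The earlier compounds shown here showed only what a bromo does on the shared core, where the step of a number 11.8 percentage points lower from compound 2 to compound 3 (beyond the scatter) is larger than the usual spread of repeat measurements; the new pair adds that a bromo can take the methoxy's place on the other ring without a step of that kind, even though the one hydrogen-bond acceptor counted for methoxy is lost. No separate measurement is available to explain why the two placements of bromo read differently.

As far as these compounds go, whether an amine, a carboxylic acid or a longer chain such as butoxy on this same carbon would move the number beyond the scatter remains open. Each number also comes from a single oral dose and a single time point, so a difference between these two compounds at other doses or times remains an open question as well.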